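Swapping a halogenated benzyl group on a bis-benzylidene core

The source may hold more compounds than are shown below. What is called first, only, known or untested is meant among the compounds shown, and "the series" means these compounds.

Measured so far:
compound 1 `COc1ccc(/C=C2\CN(C(=S)SCc3cn(Cc4ccccc4Cl)nn3)C/C(=C\c3ccc(OC)cc3)C2=O)cc1`: > 100000 nM
compound 2 `O=C1/C(=C/c2ccccc2F)CN(C(=S)SCc2cn(Cc3ccccc3Cl)nn2)C/C1=C\c1ccccc1F`: 100000 nM

In a functional assay on MDA-MB-231 cells (Homo sapiens) for cytotoxicity, read by MTT assay, with a stated time of 24 h (on this read-out lower numbers stand for stronger inhibition and higher numbers for weaker inhibition), compound 1 gives > 100000 nM, which is a limit of the assay rather than a number, so compound 1 stands only at the limit of > 100000 nM in this assay, at which 1 of the 2 values shown sits. Compound 2, in this assay, gives 100000 nM. Compound 3 `COc1ccc(/C=C2\CN(C(=S)SCc3cn(Cc4ccc(F)cc4)nn3)C/C(=C\c3ccc(OC)cc3)C2=O)cc1` has not been measured yet; it differs from compound 1 by 4-fluorophenyl in place of 2-chlorophenyl on a saturated chain carbon bound to an aromatic nitrogen. Among the measured compounds shown here, with no measured step to lean on and both known values at the edge of the assay, I expect the step from compound 1 to compound 3 in this assay to be a number no higher from compound 1 to compound 3 (the limit leaves the size open), no more than the scatter. Compound 3 is therefore estimated at 100000 nM, within 50000 nM to 200000 nM.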

Compound 3, half-maximal inhibitory concentration: > 100000 nM
Compound 3: only a limit was reported; the forecaster's own chance of this, stated with the estimate: 65%; the middle value sits exactly at the limit.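

Among the compounds shown here, no step from compound 1 to compound 3 can be read, as both stop at a limit rather than a number: the limit of > 100000 nM in this assay, at which 2 of the 3 values shown sit. The compounds shown leave open whether changing 2-chlorobenzyl to 4-fluorobenzyl alters the result in this assay.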